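Methylsulfanyl on the methoxy carbon: a partition estimate

The compounds below may be only part of what the source reports. "The series", "measured", "known", "first", "only" and "open" are said of these compounds alone.

Measured compounds:
compound 1, `CCCCc1c(Cl)cc(N/C=N/OCC)cc1Cl`, a physicochemical assay for lipophilicity, measured as octanol-water partition; a higher number here means a more lipophilic compound, a lower number a more polar compound: 5.6
compound 2, `CCO/N=C/Nc1cc(Cl)c(OCC#N)c(Cl)c1`, this assay: 3.1
compound 3, `C#CCc1c(Cl)cc(N/C=N/OC)cc1Cl`, this assay: 3.3

Compound 3 stands second highest of the three numbers in this assay. Its nearest neighbour is compound 2, which gives 3.1, a value within the scatter of compound 3, so no order between the two can be read. Compound 1, with 5.6, lies well beyond the scatter above compound 3.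

Compound 4, `C#CCc1c(Cl)cc(N/C=N/OCSC)cc1Cl`, has not yet been measured in this assay. It differs from compound 3 in one place: methylsulfanyl in place of hydrogen on a saturated chain carbon bound to an oxygen.

For the measured compounds named here, the only measured step, a number 2.50 log units lower from compound 1 to compound 2 (beyond the scatter), concerns a different change and does not bear directly on this one. Going by the values given here, no measured pair shows the effect of methylsulfanyl in place of hydrogen. The estimate therefore rests on the change itself, which enters two heavy atoms and no donor. A moderate rise in this assay is expected, and the step from compound 3 to compound 4 is estimated at a number 0.70 log units higher from compound 3 to compound 4 (beyond the scatter). Compound 4 is expected to give about 4 in this assay, most likely between 3.4 and 4.6.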

Compound 4, partition coefficient: 3.6
Compound 4: the middle estimate sits 0.40 log units above what was measured; low and high end bracket the measured number.
By their numbers in this assay, from the lowest: compounds 2, 3 and 4 (each within the scatter of the next, the first and the last beyond it); then compound 1.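

Methylsulfanyl in place of hydrogen on a saturated chain carbon bound to an oxygen now has a measured step of its own, which the earlier compounds did not provide: in this assay the change reads as a number 0.30 log units higher from compound 3 to compound 4 (within the scatter). Going from methoxy to (methylsulfanyl)methoxy at this position, with its 2 heavy atoms entering, therefore leaves the two compounds without a readable order in this read-out. Nothing available here accounts for the size of this step.

As far as these compounds go, whether an amine, a carboxylic acid or a longer chain such as butylsulfanyl on the same carbon would give a step beyond the scatter remains open. So does whether methylsulfanyl would give a step of similar size on a saturated chain carbon in another compound.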